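The compounds below may be only part of what the source reports. "The series", "measured", "known", "first", "only" and "open" are said of these compounds alone.

Of the compounds shown here, three have been tested in a functional assay on SMMC-7721 cells (Homo sapiens) for cytotoxicity, read by MTT assay, with a stated time of 72 h (on this read-out lower numbers stand for stronger inhibition and higher numbers for weaker inhibition), and a fourth has not. Compound 1 `CCNC(=O)N1CCN(C(=S)SCc2cn(Cc3ccccc3F)nn2)CC1` is the starting point. In this assay compound 1 reaches only the limit of the measurement, > 128000 nM. Compound 2 `CC(C)NC(=O)N1CCN(C(=S)SCc2cn(Cc3ccccc3F)nn2)CC1` differs from compound 1 by methyl in place of hydrogen on a saturated chain carbon bound to an amide-type nitrogen and a saturated chain carbon. In this assay compound 2 gives 7130 nM, which makes the step of an at least 17-fold lower number from compound 1 to compound 2 (1.25 log units; beyond the scatter). Compound 3 `CCNC(=O)N1CCN(C(=S)SCc2cn(Cc3ccc(C)cc3)nn2)CC1` keeps the same substituent pattern as compound 1 but carries a different core; the cores differ by 4-methylphenyl in place of 2-fluorophenyl on a saturated chain carbon bound to an aromatic nitrogen. In this assay compound 3 also stops at the limit, > 128000 nM. The step that the two limits leave unreadable from compound 1 to compound 3 cannot be read because two values sit at the limit of > 128000 nM in this assay, at which 2 of the 3 values shown sit, so the core change itself is of unknown size.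

Compound 4 `Cc1ccc(Cn2cc(CSC(=S)N3CCN(C(=O)NC(C)C)CC3)nn2)cc1` is not yet measured. It differs from compound 3 by methyl in place of hydrogen on a saturated chain carbon bound to an amide-type nitrogen and a saturated chain carbon, the same change, at the same place, that turned compound 1 into compound 2. Among the four compounds that change appears twice in all. Within the data shown here, its one measured instance was large, and on that basis the step from compound 3 to compound 4 is expected to be an at least 10-fold lower number from compound 3 to compound 4 (1.02 log units; beyond the scatter), resting on the step of an at least 17-fold lower number from compound 1 to compound 2 (1.25 log units; beyond the scatter). Because compound 3 is known only as a limit, > 128000 nM, the expected size is uncertain. Compound 4 is estimated to give about 12000 nM in this assay, between 3000 nM and 100000 nM.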

Compound 4, half-maximal inhibitory concentration: > 128000 nM
Compound 4: no number, only a limit (the forecaster's own chance of this, stated with the estimate: 25%); middle value at least 10-fold (1.02 log units) away from the limit.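

In this assay compound 4 gives > 128000 nM, which is a limit of the measurement and not a number. With the isopropyl group kept, 4-methylphenyl in place of 2-fluorophenyl gives an at least 17-fold higher number from compound 2 to compound 4 (1.25 log units; beyond the scatter), so the change from ethyl to isopropyl, which brought a measurable value on the core of compound 1, brought none on the core of compound 3. This does not show that the change has no effect on that second core, since a step between two limits cannot be read: the limit of > 128000 nM in this assay, at which 3 of the 4 values shown sit.

The compounds shown leave open whether a longer chain such as butyl in place of the isopropyl group would give a measurable value on the core of compound 3. They also leave open how an unsubstituted phenyl in place of 2-fluorophenyl or 4-methylphenyl would behave with the isopropyl group kept, which would help show how far the value of compound 2 depends on its fluorine.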